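A few compounds are considered here, and "the series" means these few. Any claim that something is new, unique, unknown or untested is made for them only; others in the source may bear on it.

For the measured compounds named here, compound 1 `COc1ccc(Br)cc1C(C)NC(=O)N(C)S(=O)(=O)c1ccccc1` was tested in a functional assay on trachea (Rattus norvegicus, strain Wistar), with a stated time of 15 min (on this read-out lower numbers stand for an effect already at smaller amounts and higher numbers for an effect only at larger amounts of compound), where compound 1 gives 8400 nM, the lower of the two numbers measured so far. Compound 2 `Cc1ccc(OCc2ccccc2)c(C(C)NC(=O)NS(=O)(=O)c2ccc(Cl)cc2)c1` in this assay gives 30400 nM, a gap beyond the usual scatter, so compound 2 acts only at larger amounts. Compound 3 `COc1ccc(Br)cc1C(C)NC(=O)N(C)S(=O)(=O)c1ccc(C)cc1` has not yet been measured in this assay; it differs from compound 1 by methyl in place of hydrogen on an aromatic carbon. Going by the values given here, no measured pair shows this change, so the step of a 1.2-fold lower number from compound 1 to compound 3 (0.08 log units; within the scatter) is expected to be small, in either direction, within the scatter. Compound 3 is therefore expected to give about 7000 nM, between 3000 nM and 20000 nM.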

Compound 3, half-maximal effective concentration: 12800 nM
Compound 3: middle estimate off by 1.8-fold (0.26 log units), on the low side, within the range that was stated.
By their numbers in this assay, from the lowest: compounds 1 and 3 (each within the scatter of the next); then compound 2.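

In this assay the change from phenyl to 4-methylphenyl gives a 1.5-fold higher number from compound 1 to compound 3 (0.18 log units; within the scatter) and so stays within the usual scatter. For the compounds shown here, this position, para to a large group, therefore accepts one added methyl with no change that can be told from repeat-measurement noise, which the earlier compounds, with no pair differing in one place, could not show. No available evidence offers an explanation for this result.

As far as these compounds go, whether an amine, a carboxylic acid or a longer chain at this position would move the number stays open.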